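This account rests on a few compounds, and the source may have more. Where it says the series, first, only, none or still open, it means among the compounds named here.

Measured compounds in the series:

- compound 1, `CCc1ccc(Nc2[nH]c(C)nc3nccc2-3)cc1`: 214000000 nM
- compound 2, `CCCc1ccc(Nc2[nH]c(C)nc3nccc2-3)cc1`: 105000000 nM
- compound 3, `Cc1nc2nccc-2c(NC(C)C)[nH]1`: 550000000 nM

All three were run in a functional assay on the whole organism for inhibition, with Nicotiana tabacum as the target; a lower number here means a stronger inhibitor, a higher number a weaker inhibitor. For the measured compounds named here, compound 3 carries an isopropylamino group on the shared core, where compound 1 and compound 2 carry a substituted anilino group; the difference between the two cores is not broken down here, and the numbers show only that compound 3 stands highest of the three.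

Between compound 1 and compound 2 the change is methyl in place of hydrogen on a saturated chain carbon, two bonds along the chain from an aromatic carbon. In this assay it gave a 2.0-fold lower number from compound 1 to compound 2 (0.31 log units; beyond the scatter).

Compound 4, `CCC(C)Nc1[nH]c(C)nc2nccc1-2`, is not yet measured. It differs from compound 3 by methyl in place of hydrogen on a saturated chain carbon, two bonds along the chain from a nitrogen on an aromatic ring. Going by the values given here, this is the same kind of change as the one from compound 1 to compound 2, though not the same: there the added methyl sits two bonds along the chain from an aromatic carbon, here two bonds along the chain from a nitrogen on an aromatic ring. Among the compounds with values here, only one prior instance of this kind of change exists, so the expectation rests on that single step.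

For compound 4 in this assay a step of about a 1.8-fold lower number from compound 3 to compound 4 (0.26 log units; within the scatter) is expected, modelled on the step from compound 1 to compound 2 and starting from the value of compound 3, 550000000 nM. Compound 4 is therefore estimated at 300000000 nM, with a plausible range from 150000000 nM to 650000000 nM.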

Compound 4, half-maximal inhibitory concentration: 174000000 nM
For compound 4 the middle estimate is 1.7-fold (0.24 log units) above the measured one; measured number inside the range.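

Working notes on the methyl change. In this assay, methyl in place of hydrogen on a saturated chain carbon, two bonds along the chain from a nitrogen on an aromatic ring, turns the isopropylamino group into a (sec-butyl)amino group and gives a 3.2-fold lower number from compound 3 to compound 4 (0.50 log units; beyond the scatter). Set beside the earlier step on the chain of the anilino compounds, this step points the same way and cannot be told apart from it in size: the same change on two cores in this assay, a 2.0-fold lower number (0.31 log units; beyond the scatter) from compound 1 to compound 2 and a 3.2-fold lower number (0.50 log units; beyond the scatter) from compound 3 to compound 4, 1.6-fold (0.19 log units) apart, within the scatter of two such steps. So within these four compounds the added methyl carries over from one core to the other with the number falling both times and no compound going against this, but two steps do not make a general rule, the two places are not identical, and nothing here shows why the number falls.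

The compounds shown leave open whether the same step would appear on a longer chain than sec-butyl, or whether a hydroxyl group, an amine or a carboxylic acid at the same chain carbon would move the number in the same direction. They also leave open how a cyclic group such as cyclopentyl on the amino nitrogen would compare with the open chains.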